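Replacing methoxymethoxy with fluoro on the shared core

This account rests on a few compounds, and the source may have more. Where it says the series, first, only, none or still open, it means among the compounds named here.

In a functional assay on HL-60 cells (Homo sapiens) for cytotoxicity, read by WST assay, with a stated time of 48 h (on this read-out lower numbers stand for an effect already at smaller amounts and higher numbers for an effect only at larger amounts of compound), compound 1 (`COc1ccccc1C[C@H]1C(=O)OC[C@@H]1Cc1ccccc1`) gives 79000 nM, compound 2 (`COCOc1ccccc1C[C@H]1C(=O)OC[C@@H]1Cc1ccccc1`) gives 76000 nM and compound 3 (`O=C1OC[C@H](Cc2ccccc2)[C@H]1Cc1ccccc1C(F)(F)F`) gives 37000 nM. Compound 2 thus sits level with compound 1, and both numbers are clearly higher than that of compound 3. Compound 4 (`O=C1OC[C@H](Cc2ccccc2)[C@H]1Cc1ccccc1F`) has fluoro in place of methoxymethoxy on an aromatic carbon. The closest measured change puts trifluoromethyl at that carbon and gives a 2.1-fold lower number from compound 2 to compound 3 (0.31 log units; beyond the scatter). The change with methoxy leaving gives a 2.1-fold lower number from compound 1 to compound 3 (0.33 log units; beyond the scatter). Both steps are modest, and fluoro is a smaller group, so a shift toward lower numbers that stays within the scatter is expected. The expected change is a 1.5-fold lower number from compound 2 to compound 4 (0.16 log units; within the scatter). For compound 4 the estimated value is 52000 nM, with an expected range of 28000 nM to 90000 nM.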

Compound 4, half-maximal effective concentration: 72000 nM
Compound 4: middle estimate off by 1.4-fold (0.14 log units), on the low side, and the stated range covers the measured number.
By their numbers in this assay, from the lowest: compounds 3, 4, 2 and 1 (each within the scatter of the next, the first and the last beyond it).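

In this assay, fluoro on this aromatic carbon cannot be told apart from any of the three groups it was compared with: methoxymethoxy (a 1.1-fold lower number from compound 2 to compound 4 (0.02 log units; within the scatter)), methoxy (a 1.1-fold lower number from compound 1 to compound 4 (0.04 log units; within the scatter)) or trifluoromethyl (a 1.9-fold higher number from compound 3 to compound 4 (0.29 log units; within the scatter)). Compounds 1 and 3 are separated beyond the scatter, yet compound 4 lies within the scatter of both. No measurement shown gives a reason for this.

Still open, as far as these compounds go, is how an amine or a carboxylic acid on this carbon would read, and whether a longer chain would stay within the scatter of compound 2.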